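The compounds below may be only part of what the source reports. "The series", "measured", "known", "first", "only" and "open" are said of these compounds alone.

The series shares one core and varies only in the aryl amide portion. In a functional assay on MV4-11 cells (Homo sapiens) for antiproliferative activity, with a stated time of 6 days, tested at 1.56 uM (on this read-out lower numbers stand for a weaker effect and higher numbers for a stronger effect at the one concentration tested), compound 1 `CNC(=O)N1CCCc2ccc(NC(=O)c3ccc(-c4cc[nH]n4)cc3)cc21` gives 92.5%, the highest of the three numbers at hand. Compound 2 `CNC(=O)N1CCCc2ccc(NC(=O)c3cccc(-c4ccccc4)c3)cc21` gives 2.83%, and compound 3 `CNC(=O)N1CCCc2ccc(NC(=O)c3cccc(-c4cc[nH]n4)c3)cc21` gives 27.3%; compound 1 stands beyond the scatter above both of them. Among the compounds with values here, the single step between measured compounds that differ in one place, a number 24.5 percentage points higher from compound 2 to compound 3 (beyond the scatter), puts a 1H-pyrazol-3-yl in place of a phenyl and is modest in size.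

Compound 4 `CNC(=O)N1CCCc2ccc(NC(=O)c3ccc(-c4cn[nH]c4)cc3)cc21` has not yet been measured. It differs from compound 1 by 1H-pyrazol-4-yl in place of 1H-pyrazol-3-yl on an aromatic carbon, the two having the same atoms joined differently. Within the data shown here, no measured step bears directly on this exchange of one pyrazole isomer for another, so the expectation rests on indirect evidence. Among the measured compounds shown here, the one known step shows that a pyrazole is well tolerated, and compound 1 already sits near the top of the read-out, which leaves little room for a gain. The expected step of a number 17.5 percentage points lower from compound 1 to compound 4 (beyond the scatter) is therefore a small to moderate loss that still leaves compound 4 among the stronger members. Compound 4 is expected to give 75%, with a range from 30% to 97%.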

Compound 4, a percentage reported as inhibition, at one concentration (the size of the read-out at that concentration, not a potency): 73.5%
The estimate for compound 4 lay 1.5 percentage points above the measured number; the measured number falls inside the stated range.
By their numbers in this assay, from the lowest: compound 2; then compound 3; then compound 4; then compound 1.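

Read in this assay, 1H-pyrazol-4-yl in place of 1H-pyrazol-3-yl gives a number 19 percentage points lower from compound 1 to compound 4 (beyond the scatter), a modest step, and it is the first measured change that keeps the atoms of the group and alters only how they are joined. Para to a large group, the point of attachment of the pyrazole therefore registers in this read-out, even though the leaving and entering groups have the same heavy atoms, the same hydrogen-bond donor and acceptor counts and no net charge, while compound 4 at 73.5% retains a sizeable effect at the one concentration tested. Nothing in the data at hand gives a reason for the gap between the two isomers.

The compounds shown leave open how other groups at this place would read, such as an imidazole, an amine or a carboxylic acid, and whether 1H-pyrazol-4-yl would fare differently in the setting of compound 3. Since each number comes from a single concentration, they also leave open how far the two pyrazole isomers differ in potency.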